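From hydroxy to acetoxy on compound 3

A few compounds are considered here, and "the series" means these few. Any claim that something is new, unique, unknown or untested is made for them only; others in the source may bear on it.

Measured so far in a functional assay on U-373MG ATCC cells for cytotoxicity against U373 MG (Homo sapiens), read by colorimetric assay and MTT assay; a lower number here means a stronger inhibitor, a higher number a weaker inhibitor
Compound 1 `COc1cc(OC)c2cc(-c3ccc(OCc4ccccc4)cc3)c(O)nc2c1` gives 10000 nM
Compound 2 `COc1ccc(-c2cc3c(OC)cc(OC)cc3n(CCC#N)c2=O)cc1` gives 10000 nM
Compound 3 `COc1cc(OC)c2cc(-c3ccc(O)cc3)c(=O)n(C)c2c1` gives 10000 nM

Compound 3 stands level with compound 1 and compound 2. The three readings match, so the numbers do not rank these compounds. The next compound to be tested is compound 4 `COc1cc(OC)c2cc(-c3ccc(OC(C)=O)cc3)c(=O)n(C)c2c1`, which is made from the structure of compound 3 by one small edit. An acetyl group takes the place of hydrogen on an oxygen on an aromatic ring, turning hydroxy into acetoxy (acetyl in place of hydrogen on an oxygen on an aromatic ring).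

Going by the values given here, no pair of measured compounds differs in only one place, so the data give no direct guide to the size of such a step. Among the compounds with values here, the only guide is the common level, with compound 1 at 10000 nM and compound 3 at 10000 nM despite their different substituents. In this assay the expected change is no change at the digits printed from compound 3 to compound 4 (within the scatter) and so none beyond the scatter. For compound 4 the estimated value is 10000 nM (expected range 4000 nM to 20000 nM).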

Compound 4, half-maximal inhibitory concentration: 10000 nM
Compound 4: middle estimate and measured number agree at the digits printed; low and high end bracket the measured number.
By their numbers in this assay, from the lowest: compounds 1, 2, 3 and 4 (each within the scatter of the next).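

In this assay the edit from hydroxy to acetoxy gives no change at the digits printed from compound 3 to compound 4 (within the scatter) and so supplies the first direct measure of a single change in this set. Going by these compounds alone, at this oxygen on an aromatic ring, then, acetyl can stand in place of hydrogen with no shift beyond the usual scatter, something the earlier compounds, which all differ in more than one place, could not show. No measurement here bears on why the reading holds steady.

From the compounds shown here alone, it remains open whether any other group on this oxygen would move the reading, such as a longer acyl chain like hexanoyl, or an acyl chain ending in an amine or a carboxylic acid. The four compounds also leave open which single change, here or elsewhere on the shared core, would separate one compound from another in this assay.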